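Replacing the Amine of Compound 1

The compounds below may be only part of what the source reports. "The series", "measured", "known", "first", "only" and "open" are said of these compounds alone.

Compound 1 `COc1cc(OC)c(C(=O)/C=C/c2ccccc2Cl)c(O)c1CN1CCCCC1` gives 2800 nM
Compound 2 `COc1cc(O)c2c(=O)cc(-c3ccccc3Cl)oc2c1CN1CCCCC1` gives 45500 nM

In a functional assay on A549 cells (Homo sapiens) for antiproliferative activity, with a stated time of 72 h (a lower number here means a stronger inhibitor, a higher number a weaker inhibitor), compound 1 holds the lower of the two numbers, and compound 2 sits well above it, beyond the scatter. The unmeasured compound 3 `CCN(CC)Cc1c(OC)cc(OC)c(C(=O)/C=C/c2ccccc2Cl)c1O` has diethylamino in place of piperidin-1-yl on a saturated chain carbon bound to an aromatic carbon. Among the compounds with values here, no measured pair shows this change, so the expectation rests on the modest structural difference alone. The expected step of a 1.3-fold higher number from compound 1 to compound 3 (0.10 log units; within the scatter) is none beyond the scatter in this assay here. The estimated value for compound 3 is 3500 nM (expected range 1400 nM to 9000 nM).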

Compound 3, half-maximal inhibitory concentration: 3600 nM
Compound 3: middle estimate off by 1.0-fold (0.01 log units), on the low side; measured number inside the range.
By their numbers in this assay, from the lowest: compounds 1 and 3 (each within the scatter of the next); then compound 2.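

In this assay, diethylamino in place of piperidin-1-yl on a saturated chain carbon bound to an aromatic carbon gives a 1.3-fold higher number from compound 1 to compound 3 (0.11 log units; within the scatter). This single-place change shows that, for this pair, the ring of piperidin-1-yl is not required for activity at this level, since the open diethylamino group gives a value within the scatter. No available evidence explains this result. The compounds shown leave open how morpholin-4-yl, a primary amine or a carboxylic acid would read at this place.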